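A Fluorinated Hydroxyphenyl Group Replaces 3-Hydroxyphenyl

The source may report more compounds than this note shows. Statements on the series, on what has been measured and on what is new or still open speak of the compounds shown alone.

In a functional assay on PC-3 cells (Homo sapiens) for antiproliferative activity, read by MTT assay, with a stated time of 72 h (on this read-out lower numbers stand for stronger inhibition and higher numbers for weaker inhibition), compound 1 `C/C(=N\NC(=O)c1cccc(S(=O)(=O)N2CCOCC2)c1)c1ccc(F)cc1` gives 81300 nM. Compound 2 `C/C(=N\NC(=O)c1cccc(S(=O)(=O)N2CCOCC2)c1)c1cccc(O)c1` gives > 100000 nM, which is a limit of the assay and not a number. Compound 2 thus stands at the limit of > 100000 nM in this assay, at which 1 of the 2 values shown sits. Among the compounds with values here, the one measured step is an at least 1.2-fold higher number from compound 1 to compound 2 (0.08 log units; that floor lies within the scatter), so it shows no clear change when 3-hydroxyphenyl takes the place of 4-fluorophenyl. Compound 3 `C/C(=N\NC(=O)c1cccc(S(=O)(=O)N2CCOCC2)c1)c1cc(F)ccc1O` carries 5-fluoro-2-hydroxyphenyl in place of 3-hydroxyphenyl on a carbon with a double bond to nitrogen. Within the data shown here, no measured step tests this new group, so the forecast rests on thin ground. Compound 1 does reach a measurable 81300 nM with a fluorine on its ring, which tilts the expectation towards stronger inhibition. The expected change is an at least 6.6-fold lower number from compound 2 to compound 3 (0.82 log units; beyond the scatter), and it is uncertain in size. For compound 3 the estimate is 15000 nM, with an expected range from 1000 nM to 100000 nM.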

Compound 3, half-maximal inhibitory concentration: 4410 nM
For compound 3 the middle estimate is 3.4-fold (0.53 log units) above the measured one, and the stated range covers the measured number.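

Within the data shown here, at this position on the carbon with a double bond to nitrogen, the earlier compounds showed no clear change, but 5-fluoro-2-hydroxyphenyl gives an at least 22-fold lower number from compound 2 to compound 3 (1.35 log units; beyond the scatter) in this assay. Compound 2 is only a limit of the assay and not a number: the limit of > 100000 nM in this assay, at which 1 of the 3 values shown sits. The measured comparison with 4-fluorophenyl gives an 18-fold lower number from compound 1 to compound 3 (1.27 log units; beyond the scatter), so this position can carry a large change, and among these three compounds only the ring with both a fluorine and a hydroxy group gives it.

The compounds shown cannot say how much of the gain belongs to the fluorine and how much to where the hydroxy group sits, as the rings of compound 2 and compound 3 differ in both. From the compounds shown here alone, whether an amine or a methoxy group could stand in for that hydroxy group also stays open.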